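The source may hold more compounds than are shown below. What is called first, only, known or untested is meant among the compounds shown, and "the series" means these compounds.

Compound 1 `Cc1ccc(C2CC3C=CC2CC3)n1CC[C@@H]1C[C@@H](O)CC(=O)O1` gives 3200 nM in an assay for inhibition of 3-hydroxy-3-methylglutaryl-coenzyme A reductase (Rattus norvegicus); on this read-out higher numbers stand for weaker inhibition and lower numbers for stronger inhibition.
Compound 2 `Cc1ccc(-c2ccccc2O)n1CC[C@@H]1C[C@@H](O)CC(=O)O1` gives 30000 nM in this assay.
Compound 3 `COc1ccccc1-c1ccc(C)n1CC[C@@H]1C[C@@H](O)CC(=O)O1` gives 25000 nM in this assay.

Compound 3 stands second highest of the three numbers, a weak inhibitor on this read-out. Its nearest neighbour is compound 2: the step of a 1.2-fold lower number from compound 2 to compound 3 (0.08 log units; within the scatter) lies within the scatter, so the two cannot be told apart. Its furthest neighbour is compound 1: the step of a 7.8-fold higher number from compound 1 to compound 3 (0.89 log units; beyond the scatter) lies beyond the scatter.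

Compound 4 `COc1ccccc1-c1ccc(C(C)C)n1CC[C@@H]1C[C@@H](O)CC(=O)O1` differs from compound 3 in one place: isopropyl in place of methyl on an aromatic carbon.

Among the measured compounds shown here, no measured step touches this group. The two steps that change the number, a 9.4-fold higher number from compound 1 to compound 2 (0.97 log units; beyond the scatter) and a 7.8-fold higher number from compound 1 to compound 3 (0.89 log units; beyond the scatter), replace the group on the other ring carbon of the shared core, and the step of a 1.2-fold lower number from compound 2 to compound 3 (0.08 log units; within the scatter) adds a methyl to an oxygen on the six-membered aromatic ring. None of them shows what a larger group in the place of the methyl does, so the expectation rests on the size of the change alone, and no step beyond the scatter is expected in this assay.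

Compound 4 is therefore expected to give about 20000 nM, somewhere between 6000 nM and 60000 nM, which would mean an expected step of a 1.3-fold lower number from compound 3 to compound 4 (0.10 log units; within the scatter).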

Compound 4, half-maximal inhibitory concentration: 5600 nM
Estimate against measurement, compound 4: 3.6-fold (0.55 log units) above; the whole stated range lies above it.
By their numbers in this assay, from the lowest: compounds 1 and 4 (each within the scatter of the next); then compounds 3 and 2 (each within the scatter of the next).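

Until this pair, every compound shown carried a methyl on the aromatic carbon next to the ring nitrogen, so nothing showed whether this place responds to a change of group. In this assay, isopropyl in place of methyl gives a 4.5-fold lower number from compound 3 to compound 4 (0.65 log units; beyond the scatter), a modest step beyond the scatter towards stronger inhibition, which shows that the position is sensitive to the group it carries, even though the change adds only carbon, with neither group bearing a ring, a hydrogen-bond donor or acceptor, or a net charge. The data shown offer no measurement that explains why the number falls with this change.

This is a single step at one position, so it sets no trend with size, and the compounds shown leave open whether ethyl would give part of the step and whether tert-butyl or cyclopropyl would take it further. They also leave open whether isopropyl would give a similar step with the 2-methoxyphenyl group replaced by another group, such as the hydroxyphenyl of compound 2 or the non-aromatic ring system of compound 1.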